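The source may hold more compounds than are shown below. What is called first, only, known or untested is meant among the compounds shown, and "the series" means these compounds.

Compound 3 `CCCCCC#Cc1cn(C/C=C/CN2C(=O)c3ccccc3C2=O)c(=O)[nH]c1=O` gives only a limit in a functional assay on L1210 cells (Mus musculus) for antiproliferative activity, read by MTT assay, with a stated time of 2 days (a higher number here means a weaker inhibitor, a lower number a stronger inhibitor), namely > 500000 nM. Compound 2 `CCCCCCC#Cc1cn(C/C=C/CN2C(=O)c3ccccc3C2=O)c(=O)[nH]c1=O` gives 43000 nM in this assay, and compound 1 `CCCCCCCCC#Cc1cn(C/C=C\CN2C(=O)c3ccccc3C2=O)c(=O)[nH]c1=O` gives 45000 nM. Within the data shown here, the one step bearing on the series is an at least 11-fold higher number from compound 2 to compound 3 (1.06 log units; beyond the scatter), so shortening the chain on the triple-bonded carbon cost potency, with compound 3 sitting at the limit of > 500000 nM in this assay, at which 1 of the 3 values shown sits. Compound 4 `CCCCc1ccc(C#Cc2cn(C/C=C/CN3C(=O)c4ccccc4C3=O)c(=O)[nH]c2=O)cc1` carries the change (4-butylphenyl in place of pentyl on a triple-bonded carbon), which returns length to that position, though as an aromatic group rather than a chain. From compound 3 to compound 4 a return toward the numbers of compounds 1 and 2 is expected, as an at least 8.3-fold lower number from compound 3 to compound 4 (0.92 log units; beyond the scatter). Compound 4 is therefore estimated at 60000 nM in this assay, with a plausible span from 20000 nM to 300000 nM.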

Compound 4, half-maximal inhibitory concentration: 42000 nM
Compound 4: the middle estimate sits 1.4-fold (0.15 log units) above what was measured; low and high end bracket the measured number.
By their numbers in this assay, from the lowest: compounds 4, 2 and 1 (each within the scatter of the next). At a limit, above all of these: compound 3.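

The position on the triple-bonded carbon accepts an aromatic ring: 4-butylphenyl in place of pentyl gives an at least 11-fold lower number from compound 3 to compound 4 (1.07 log units; beyond the scatter). Compound 3 stands only at a limit: the limit of > 500000 nM in this assay, at which 1 of the 4 values shown sits. Set against hexyl, 4-butylphenyl gives a 1.0-fold lower number from compound 2 to compound 4 (0.01 log units; within the scatter), so in this assay the ring-bearing group and the chain cannot be told apart.

Open, on these data alone, is whether the butyl on the phenyl ring is needed, or whether an unsubstituted phenyl would hold the number. Also open, as far as these compounds go, is how a phenyl ring carrying an amine or a carboxylic acid would read at this position.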